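Compound 3 and an added ethoxy group

The source may hold more compounds than are shown below. What is called first, only, known or untested is meant among the compounds shown, and "the series" means these compounds.

In a functional assay on MCF7 cells (Homo sapiens) for antiproliferative activity, read by sulforhodamine B assay, with a stated time of 72 h (on this read-out higher numbers stand for weaker inhibition and lower numbers for stronger inhibition), compound 1 (`COc1cc2occ(-c3csc4ccccc34)c(=O)c2c(OC)c1O`) gives only a limit, > 10000 nM. Compound 2 (`O=C(/C=C/c1csc2ccccc12)c1cccc(Cl)c1`) also gives only a limit, > 10000 nM. Compound 3 (`O=C(/C=C/c1csc2ccccc12)c1ccccc1O`) is the only one of the three with a measured number, 6600 nM. Compound 4 (`CCOc1ccc(O)c(C(=O)/C=C/c2csc3ccccc23)c1`) differs from compound 3 by one change, (ethoxy in place of hydrogen on an aromatic carbon). Among the compounds with values here, no measured pair shows what such a change does in this assay, so the only anchor is compound 3 at 6600 nM, and no shift beyond the usual scatter is expected. The expected change is a 1.3-fold lower number from compound 3 to compound 4 (0.12 log units; within the scatter), with no firm direction. For compound 4 the estimated value is 5000 nM, with an expected range from 2000 nM to 10000 nM.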

Compound 4, half-maximal inhibitory concentration: 7500 nM
Compound 4: the middle estimate sits 1.5-fold (0.18 log units) below what was measured, and the stated range covers the measured number.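

Within the data shown here, compound 4 gives the first readable step at this position, on the aromatic carbon para to a hydroxy group and meta to a large group: in this assay the series shows a 1.1-fold higher number from compound 3 to compound 4 (0.06 log units; within the scatter) when ethoxy replaces hydrogen there. Ethoxy at this carbon therefore leaves compound 4 and compound 3 indistinguishable on this read-out. Nothing shown here gives a cause for this result.

On these data alone, whether an amine, a carboxylic acid or a longer chain at this carbon would shift the number beyond the scatter remains open. So does the effect of removing the hydroxy group.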